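A few compounds are considered here, and "the series" means these few. Any claim that something is new, unique, unknown or untested is made for them only; others in the source may bear on it.

In a functional assay on A549 cells (Homo sapiens) for cytotoxicity, read by MTT assay, with a stated time of 24 h (on this read-out lower numbers stand for stronger inhibition and higher numbers for weaker inhibition), compound 2 `C=CC1=C(C(=O)NCC(C)C)C(c2ccc(F)cc2)OC1` gives only a limit of the assay, > 100000 nM. Its closest measured relative, compound 1 `C=CC1=C(C(=O)NCCC)C(c2ccc(F)cc2)OC1`, likewise gives in this assay only a limit, > 100000 nM. The step between them is therefore a step that the two limits leave unreadable from compound 1 to compound 2; both values sit at the limit of > 100000 nM in this assay, at which 2 of the 2 values shown sit. The change now considered is phenyl in place of isobutyl on an amide-type nitrogen, which turns compound 2 into compound 3 `C=CC1=C(C(=O)Nc2ccccc2)C(c2ccc(F)cc2)OC1`. Going by the values given here, no measured step bears on this change: the single step between measured compounds cannot be sized, so it offers neither a direction nor a magnitude for this assay. With compound 2 at a limit, compound 3 is expected to remain near that same limit, an estimated step of a number no higher from compound 2 to compound 3 (the limit leaves the size open). The estimate for compound 3 in this assay is 100000 nM, within an expected range from 30000 nM to 300000 nM, with a considerable chance that again only a limit is reported.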

Compound 3, half-maximal inhibitory concentration: > 100000 nM
Compound 3: a limit, no number; the forecaster's own chance of this, stated with the estimate: 70%; the middle value lies on the limit itself.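

Compound 3 gives > 100000 nM in this assay, which is a limit and not a number. No step among compound 1, compound 2 and compound 3 can be read: the limit of > 100000 nM in this assay, at which 3 of the 3 values shown sit.

The compounds shown leave open whether phenyl, isobutyl or propyl on the amide-type nitrogen makes any difference in this assay.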